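The compounds below may be only part of what the source reports. "The series", "measured", "known", "first", "only" and "open" are said of these compounds alone.

Among the three measured compounds, compound 2 `c1ccc(-c2cc(NCC3CC3)ncn2)nc1` gives the highest number in a functional assay on HEK293 cells for agonist activity at G-protein coupled receptor 39 (Homo sapiens), read by inositol phosphate accumulation (on this read-out lower numbers stand for an effect already at smaller amounts and higher numbers for an effect only at larger amounts of compound), at 22000 nM. Going by the values given here, compound 1 `CNc1nc(NCc2ccc(OC(F)(F)F)cc2)cc(-c2ccccn2)n1` gives 13 nM and compound 3 `CNc1nc(NCc2ccc(NC(C)=O)cc2)cc(-c2ccccn2)n1` gives 5 nM; the one measured step, a 2.6-fold lower number from compound 1 to compound 3 (0.41 log units; beyond the scatter), concerns a group elsewhere in the molecule and does not touch the place changed here. Compound 4 `CN(C)c1nc(NCC2CC2)cc(-c2ccccn2)n1` differs from compound 2 by dimethylamino in place of hydrogen on an aromatic carbon. Among the compounds with values here, no measured pair isolates this change, since compounds 1 and 3 carry a methylamino group there together with a different amine, so the size of the effect is uncertain. For compound 4 a large step down in this assay is nevertheless expected, a 22-fold lower number from compound 2 to compound 4 (1.34 log units; beyond the scatter). Compound 4 is therefore estimated at 1000 nM, between 100 nM and 10000 nM.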

Compound 4, half-maximal effective concentration: > 25000 nM
Compound 4: a limit, no number; the forecaster's own chance of this, stated with the estimate: 10%; middle value at least 25-fold (1.39 log units) from the limit.
By their numbers in this assay, from the lowest: compound 3; then compound 1; then compound 2. At a limit, above all of these: compound 4.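

In this assay compound 4 gives only a limit, not a number: the limit of > 25000 nM in this assay, at which 1 of the 4 values shown sits. On these data alone, the step to it is therefore a floor, an at least 1.1-fold higher number from compound 2 to compound 4 (0.05 log units; that floor lies within the scatter), and how far the number rises stays unknown. Even so, dimethylamino on this aromatic carbon, between two ring nitrogen atoms, brings no lower number than hydrogen while the (cyclopropylmethyl)amino group stays in place.

As far as these compounds go, whether a plain amino group or methylamino at this place would give a lower number with that group kept remains open. So does whether dimethylamino acts the same way alongside the amine carried by compound 3.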